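Expecting Compound 4 to Stay at the Tolerance Limit

The source may hold more compounds than are shown below. What is called first, only, known or untested is meant among the compounds shown, and "the series" means these compounds.

Of the compounds shown here, three have been tested in an ADME assay on HEK293 cells (Homo sapiens) for cytotoxicity, read by resazurin assay, with a stated time of 72 h; a higher number here means that more compound is tolerated, a lower number that less compound is tolerated. Compound 1 `COc1cccc(CNC(=O)c2nc3ccc(F)c(OCCc4ccc(N)cc4)c3c(=O)[nH]2)c1` gives > 20000 nM, which is a limit of this assay rather than a number. Compound 2 `O=C(O)c1ccc(CCOc2c(F)ccc3nc(C(=O)NCc4ccccc4)[nH]c(=O)c23)cc1` gives > 20000 nM, again only a limit. Compound 3 `COc1cc(CNC(=O)c2nc3ccc(F)c(OCCc4ccc(C(=O)O)cc4)c3c(=O)[nH]2)ccc1F` gives > 20000 nM, also a limit. Because every value shown sits at the limit of > 20000 nM in this assay, at which 3 of the 3 values shown sit, the step that the two limits leave unreadable from compound 2 to compound 3 cannot be read. Compound 4 `CC(C)c1cccc(CNC(=O)c2nc3ccc(F)c(OCCc4ccc(C(=O)O)cc4)c3c(=O)[nH]2)c1` differs from compound 3 by 3-isopropylphenyl in place of 4-fluoro-3-methoxyphenyl on a saturated chain carbon bound to an amide-type nitrogen. Within the data shown here, the one measured step at this place is therefore unreadable, so nothing points to a change in either direction. With all three values at the limit, compound 4 is expected to stay there, an expected step of a number no higher from compound 3 to compound 4 (the limit leaves the size open). The estimate for compound 4 in this assay is 20000 nM, ranging from 12000 nM to 40000 nM.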

Compound 4, half-maximal cytotoxic concentration: > 20000 nM
Compound 4 ended at the assay's limit; the forecaster's own chance of this, stated with the estimate: 85%; the middle value sits exactly at the limit.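

No step can be read from compound 2 or compound 3 to compound 4, because the values in this assay are limits, not numbers: the limit of > 20000 nM in this assay, at which 4 of the 4 values shown sit. On these data alone, how far each compound's true value lies past that limit stays open.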